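The source may hold more compounds than are shown below. What is called first, only, known or untested is meant among the compounds shown, and "the series" means these compounds.

Measured so far in a functional assay on T98G cells (Homo sapiens) for cytotoxicity, read by MTT assay, with a stated time of 48 h; on this read-out lower numbers stand for stronger inhibition and higher numbers for weaker inhibition:
compound 1, `C/C(=N/NC(=S)Nc1ccc(Cl)cc1)c1ccccn1`, 5.9 nM
compound 2, `C/C(=N\NC(=S)Nc1ccc(Cl)cc1)c1ccccn1`, 5.9 nM
compound 3, `CC(=NNC(S)=Nc1ccccc1Cl)c1ccccn1`, 1.1 nM

Compound 1 stands level with compound 2, and the two together give the highest numbers of the three. The step of no change at the digits printed from compound 1 to compound 2 (within the scatter) lies within the scatter, which fits with the fact that compounds 1 and 2 differ only in the configuration as drawn. Going by the values given here, compound 3 gives a lower number than compound 1, but no step between those two compounds has been worked out, and only the two values themselves can be compared.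

Compound 4 `C/C(=N/NC(=S)Nc1ccc(F)cc1)c1ccccn1` differs from compound 1 by fluoro in place of chloro on an aromatic carbon. Among the compounds with values here, the single measured step, no change at the digits printed from compound 1 to compound 2 (within the scatter), concerns only the configuration as drawn and leaves every substituent in place, so no measured step speaks to an exchange of one halogen for another on the shared core. The record therefore gives no direct guide to the size or direction of this change. In the absence of such a guide, compound 4 is expected to stay close to compound 1, with the step of a 1.5-fold higher number from compound 1 to compound 4 (0.18 log units; within the scatter) estimated to fall within the usual scatter. On that basis compound 4 is estimated at 9 nM in this assay, with a range from 3 nM to 30 nM.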

Compound 4, half-maximal inhibitory concentration: 17 nM
Estimate against measurement, compound 4: 1.9-fold (0.28 log units) below, within the range that was stated.
By their numbers in this assay, from the lowest: compound 3; then compounds 1 and 2 (each within the scatter of the next); then compound 4.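

In this assay, going by these compounds alone, the exchange of chloro for fluoro on an aromatic carbon, para to a large group, gives a 2.9-fold higher number from compound 1 to compound 4 (0.46 log units; beyond the scatter) and is the first step in this set to lie beyond the scatter. Within the data shown here, the earlier step showed only that a change in the configuration as drawn left the number as it was, whereas this one shows that the number does respond to which halogen sits at this position, with the chloro compound giving the lower number of the pair. The facts to hand concern configuration alone and do not bear on this halogen exchange.

With only chloro and fluoro shown at this position, it remains open whether a bromo or iodo group would extend the same direction, and whether a methyl, a methoxy or an amine would fit with the halogens or depart from them. On these data alone, it also remains open whether the configuration as drawn would matter as little with fluoro in place as it does with chloro.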